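Swapping Methyl for Chloro at the Assay Limit

The compounds below may be only part of what the source reports. "The series", "measured", "known", "first", "only" and "open" are said of these compounds alone.

Measured compounds:
Compound 1, `Cc1ccc(S(=O)(=O)Nc2ccc(-c3nc4ccccc4o3)cc2)cc1`, gives in an assay on cells for inhibition of HSP60/HSP10 (Homo sapiens), with a stated time of 60 min (on this read-out higher numbers stand for weaker inhibition and lower numbers for stronger inhibition), a value of > 100000 nM, which is a limit of the assay and not a number.
Compound 2, `COc1ccc(S(=O)(=O)Nc2ccc3oc(-c4ccccc4)nc3c2)cc1`, gives in this assay a value of > 100000 nM, which is likewise a limit and not a number.

Compound 1 therefore stands at the limit of > 100000 nM in this assay, at which 2 of the 2 values shown sit; no numerical potency is known for it. Among the compounds with values here, compound 2 shows the same limit, so the two values say only that neither compound reached a measurable inhibition, and nothing about how they stand to one another.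

Compound 3, `O=S(=O)(Nc1ccc(-c2nc3ccccc3o2)cc1)c1ccc(Cl)cc1`, has not yet been measured. It differs from compound 1 in one place: chloro in place of methyl on an aromatic carbon. Within the data shown here, no step between two measured compounds exists here, so there is no measured step to lean on for this change.

Because compound 1 sits at the limit of > 100000 nM in this assay, at which 2 of the 2 values shown sit, the exchange of one heavy atom for another on the same aromatic carbon is expected to leave compound 3 near that limit, and the step from compound 1 to compound 3 is expected to be a number no higher from compound 1 to compound 3 (the limit leaves the size open), none beyond the scatter. Compound 3 is thus estimated at 100000 nM, expected to fall between 30000 nM and 300000 nM, and most likely to be reported once more only as a limit.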

Compound 3, half-maximal inhibitory concentration: 61000 nM
Beside the measured number, compound 3's estimate is 1.6-fold (0.21 log units) above it; low and high end bracket the measured number.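

In this assay, compound 3 gives 61000 nM, the first actual number among the compounds shown, so a compound carrying chloro at this place, on an aromatic carbon para to a large group, can be read by this assay. Compound 1 gives > 100000 nM, which is a limit of the assay and not a number. On these data alone, the change from 4-methylphenyl to 4-chlorophenyl can therefore be stated only as an at least 1.6-fold lower number from compound 1 to compound 3 (0.21 log units; that floor lies within the scatter), which means that the true size of the step remains unknown and that its known minimum is too small to count as a real difference by itself.

Within the data shown here, whether another group at this place, such as bromo, an amine or a carboxylic acid, would give a number in this assay, and whether that number would differ from the one for compound 3, remains open. Compound 2 differs from compound 3 in more than one place and cannot be compared with it, and the picture still rests largely on values that are not numbers: the limit of > 100000 nM in this assay, at which 2 of the 3 values shown sit.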